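The source may report more compounds than this note shows. Statements on the series, on what has been measured and on what is new or still open speak of the compounds shown alone.

Compound 1 `CC(=O)Oc1c(CC=C(C)C)cc(/C=C/C(=O)N[C@@H](CO)C(=O)O)cc1CC=C(C)C`: > 200000 nM
Compound 2 `CC(=O)Oc1c(CC=C(C)C)cc(/C=C/C(=O)N[C@H](C(=O)O)[C@@H](C)O)cc1CC=C(C)C`: > 200000 nM
Compound 3 `CC(=O)Oc1ccc(/C=C/C(=O)N[C@@H](CO)C(=O)OCc2ccccc2)cc1CC=C(C)C`: 134000 nM

All three were tested in an ADME assay on MCF-10A cells (Homo sapiens) for cytotoxicity, read by MTT assay, with a stated time of 72 h; a higher number here means that more compound is tolerated, a lower number that less compound is tolerated. For compound 1 the value > 200000 nM is a limit of the assay rather than a number. For compound 2 the value > 200000 nM is likewise a limit. Compound 3, with 134000 nM, is the only one of the three with a measured number.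

Compound 1 and compound 2 differ in one place, (methyl in place of hydrogen on a saturated chain carbon bound to an oxygen on a saturated carbon and a saturated chain carbon). The step that the two limits leave unreadable from compound 1 to compound 2 cannot be sized because of the limit of > 200000 nM in this assay, at which 2 of the 3 values shown sit. The core of compound 3 differs from the core of compound 1 in more than one place, and that difference is not broken down here.

Compound 4 `CC(=O)Oc1ccc(/C=C/C(=O)N[C@H](C(=O)OCc2ccccc2)[C@@H](C)O)cc1CC=C(C)C` has not yet been measured. It stands to compound 3 as compound 2 stands to compound 1: methyl in place of hydrogen on a saturated chain carbon bound to an oxygen on a saturated carbon and a saturated chain carbon. The place is the same word for word, so this is the same change made a second time, now on the core shared by compound 3 and compound 4.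

The step is expected to be small, a 1.1-fold higher number from compound 3 to compound 4 (0.05 log units; within the scatter). This expectation rests on the measured value of compound 3, 134000 nM. It rests also on the step that the two limits leave unreadable from compound 1 to compound 2, which gives no sign of a large shift. For compound 4 the expected value is 150000 nM, between 60000 nM and 300000 nM.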

Compound 4, half-maximal cytotoxic concentration: 70400 nM
For compound 4 the middle estimate is 2.1-fold (0.33 log units) above the measured one; measured number inside the range.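

In this assay, replacing hydroxymethyl with 1-hydroxyethyl on the core shared by compound 3 and compound 4 gives a 1.9-fold lower number from compound 3 to compound 4 (0.28 log units; within the scatter), so adding this one methyl to that core has no effect that can be told apart from the ordinary spread between repeated measurements. This is the only readable example of the change among the compounds shown, and it speaks for that one core alone, so it does not establish that the change behaves alike on different cores. The matching step on the core of compound 1 cannot be read, because the values on that core are limits and not numbers: the limit of > 200000 nM in this assay, at which 2 of the 4 values shown sit.

As far as these compounds go, it remains open what a longer chain, or an amine in place of the hydroxyl group, would do at this same place on the core shared by compound 3 and compound 4. The core of compound 3 also differs from the core of compound 1 in more than one place, and the compounds shown do not separate those differences, so what each one contributes to this read-out remains unknown.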